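The compounds below may be only part of what the source reports. "The series", "measured", "known", "first", "only" and "open" are said of these compounds alone.

In a functional assay on HT-29 cells (Homo sapiens) for inhibition, read by luminescence and CellTiter-Glo, with a stated time of 24 h (on this read-out lower numbers stand for an effect already at smaller amounts and higher numbers for an effect only at larger amounts of compound), compound 1 (`CN1C(=S)[C@@H](NC(=O)c2nc(Cc3ccccc3)n(C)n2)COc2ccccc21`) gives 2.5 nM and compound 2 (`CCCn1nc(C(=O)N[C@H]2COc3ccccc3N(C)C2=S)nc1Cc1ccccc1`) gives 288 nM while compound 3 (`CC(C)CCn1nc(C(=O)N[C@H]2COc3ccccc3N(C)C2=S)nc1Cc1ccccc1`) stands highest of the three at 3640 nM in this set. Compound 4 (`CN1C(=S)[C@@H](NC(=O)c2nc(Cc3ccccc3)n(CCCF)n2)COc2ccccc21`) is unmeasured and differs from compound 3 by fluoromethyl in place of isopropyl on a saturated chain carbon, two bonds along the chain from an aromatic nitrogen with fluoromethyl in place of isopropyl on a saturated chain carbon, two bonds along the chain from an aromatic nitrogen. The closest evidence is a 13-fold higher number from compound 2 to compound 3 (1.10 log units; beyond the scatter) with isopropyl in place of methyl at that same place. The larger steps of a 120-fold higher number from compound 1 to compound 2 (2.06 log units; beyond the scatter) and a 1500-fold higher number from compound 1 to compound 3 (3.16 log units; beyond the scatter) run in the same direction. No fluorinated chain has been measured, yet a large step to a lower number is expected. The expected change is an 18-fold lower number from compound 3 to compound 4 (1.26 log units; beyond the scatter) on this estimate. For compound 4 the estimated value is 200 nM with an expected range of 50 nM to 800 nM as a working figure.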

Compound 4, half-maximal effective concentration: 4760 nM
Compound 4: the middle estimate sits 24-fold (1.38 log units) below what was measured; measured number above the stated range.
By their numbers in this assay, from the lowest: compound 1; then compound 2; then compounds 3 and 4 (each within the scatter of the next).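

Isopentyl and 3-fluoropropyl cannot be told apart at this position (a 1.3-fold higher number from compound 3 to compound 4 (0.12 log units; within the scatter)). Fluoro in place of hydrogen, three bonds along the chain from an aromatic nitrogen, is itself a large step (a 17-fold higher number from compound 2 to compound 4 (1.22 log units; beyond the scatter)), and 2-fluoroethyl in place of hydrogen gives a much larger one (a 1900-fold higher number from compound 1 to compound 4 (3.28 log units; beyond the scatter)), so this fluorinated chain brings no return towards compound 1. Nothing available explains these steps.

Open, from the compounds shown here alone, is whether an ethyl chain, or a chain carrying a hydroxyl or an amine, would stay nearer to compound 1.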